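Cyano in place of trifluoromethyl on a shared amide core

The source may report more compounds than this note shows. Statements on the series, on what has been measured and on what is new or still open speak of the compounds shown alone.

Three measured amides share one core. Compound 1 `COc1ccc2sc(NC(=O)c3ccc(C)cc3)nc2c1` was tested in a functional assay on MDA-MB-231 cells (Homo sapiens) for antiproliferative activity, read by sulforhodamine B assay (on this read-out lower numbers stand for stronger inhibition of growth and higher numbers for weaker inhibition of growth), where compound 1 gives only the assay limit > 10 ug/mL. Compound 2 `COc1ccc(C(=O)Nc2nc3cc(OC)ccc3s2)cc1` likewise gives only the limit > 10 ug/mL. Compound 3 `COc1ccc2sc(NC(=O)c3ccc(C(F)(F)F)cc3)nc2c1` also gives only the limit > 10 ug/mL. Because (the limit of > 10 ug/mL in this assay, at which 3 of the 3 values shown sit), none of the steps among them can be sized: a step that the two limits leave unreadable from compound 1 to compound 2, a step that the two limits leave unreadable from compound 1 to compound 3 and a step that the two limits leave unreadable from compound 2 to compound 3. Compound 4 `COc1ccc2sc(NC(=O)c3ccc(C#N)cc3)nc2c1` differs from compound 3 by cyano in place of trifluoromethyl on an aromatic carbon. Going by the values given here, no measured step bears readably on this change, so no direction or size beyond the scatter can be expected in this assay. The expected step is a step that the limit leaves unreadable from compound 3 to compound 4. Compound 4 is estimated at 15 ug/mL, within 5 ug/mL to 50 ug/mL, most likely again only a limit.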

Compound 4, concentration for 50% growth inhibition: > 10 ug/mL
Compound 4: no number, only a limit; the forecaster's own chance of this, stated with the estimate: 80%; the middle value lies beyond the limit too.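

No step linking compound 4 with compound 1, compound 2 or compound 3 can be read, since each gives only a limit: the limit of > 10 ug/mL in this assay, at which 4 of the 4 values shown sit.

These compounds leave open how the four groups would rank, and whether any of them changes growth inhibition at all.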